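Furanylethyl in place of oxadiazolylmethyl on the amide nitrogen

This account rests on a few compounds, and the source may have more. Where it says the series, first, only, none or still open, it means among the compounds named here.

In an assay on CHO cells for displacement of a labelled ligand from Orexin/Hypocretin receptor type 1 (Homo sapiens), read by radioligand binding, with a stated time of 2 h (on this read-out lower numbers stand for stronger inhibition and higher numbers for weaker inhibition), compound 1 `COc1cc(=O)n2c(c1C(=O)N(C)Cc1nonc1C)CCN(C(=O)C1(c3ccccc3)CC1)CC2` returns only the assay limit of > 100000 nM. Compound 2 `COc1ccc2cc(CN(C)C(=O)COC(=O)c3c(F)cccc3F)ccc2c1` likewise returns only the limit of > 100000 nM in this assay. Both measured values thus sit at the limit of > 100000 nM in this assay, at which 2 of the 2 values shown sit, so compound 1 has no number to stand on. Compound 3 `COc1cc(=O)n2c(c1C(=O)N(C)[C@H](C)c1ccco1)CCN(C(=O)C1(c3ccccc3)CC1)CC2` differs from compound 1 by 1-(furan-2-yl)ethyl in place of (4-methyl-1,2,5-oxadiazol-3-yl)methyl on an amide-type nitrogen. Within the data shown here, no measured step shows how this assay answers such a change; a shift beyond the scatter in either direction cannot be ruled out. The step from compound 1 to compound 3 is expected as an at least 2.5-fold lower number from compound 1 to compound 3 (0.39 log units; beyond the scatter). For compound 3 the estimate in this assay is 40000 nM, within 2000 nM to 100000 nM, with a real chance of again only a limit.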

Compound 3, half-maximal inhibitory concentration: > 100000 nM
Compound 3 was reported as a limit (the forecaster's own chance of this, stated with the estimate: 55%); at least 2.5-fold (0.39 log units) between middle value and limit.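

In this assay, among these compounds, compound 3 gives > 100000 nM, a limit; with compound 1 also only at a limit, no step from compound 1 to compound 3 can be read. The compounds shown leave open which structural change, if any, would bring a value inside the range of this assay.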